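A few compounds are considered here, and "the series" means these few. Any claim that something is new, unique, unknown or untested is made for them only; others in the source may bear on it.

Measured so far:
Compound 1 `CCN(Cc1ccccn1)c1ccc(C(=O)N2CCc3ccc(OS(N)(=O)=O)cc3C2)cc1`, 87.7%
Compound 2 `CN(C)CCCN(Cc1ccccc1)c1cccc(C(=O)N2CCc3ccc(OS(N)(=O)=O)cc3C2)c1`, 26%
Compound 3 `CCN(Cc1cccc(Br)c1)c1cccc(C(=O)N2CCc3ccc(OS(N)(=O)=O)cc3C2)c1`, 24.9%

In an assay on HEK293 cells for inhibition of Steryl-sulfatase (Homo sapiens), tested at 1 uM (a higher number here means a stronger effect of the compound at the concentration tested, a lower number a weaker effect), compound 2 gives 26%, the second highest of the three numbers. Compound 3 lies within the scatter of it, so the two cannot be ranked against each other, while compound 1 sits well above, beyond the scatter. Compound 4 `CN(C)CCN(Cc1ccccc1)c1cccc(C(=O)N2CCc3ccc(OS(N)(=O)=O)cc3C2)c1` differs from compound 2 in one place: dimethylamino in place of (dimethylamino)methyl on a saturated chain carbon, two bonds along the chain from a nitrogen on an aromatic ring. Among the compounds with values here, no measured pair shows this kind of change, so the data give no measured step of this sort. Compound 2 and compound 3 both sit low, and the change is confined to the chain. In this assay the expected step is a number 2 percentage points higher from compound 2 to compound 4 (within the scatter), none beyond the scatter in either direction. Compound 4 is estimated at 28%, between 10% and 52%.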

Compound 4, a percentage reported as inhibition, at one concentration (the size of the read-out at that concentration, not a potency): 28.6%
Beside the measured number, compound 4's estimate is 0.6 percentage points below it; the range from low to high includes it.
By their numbers in this assay, from the lowest: compounds 3, 2 and 4 (each within the scatter of the next); then compound 1.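

In this assay, within the data shown here, exchanging 3-(dimethylamino)propyl for 2-(dimethylamino)ethyl on the nitrogen gives a number 2.6 percentage points higher from compound 2 to compound 4 (within the scatter) and so is the first measured step at this place. These two chain lengths cannot be told apart in this read-out, so this difference in length, with the dimethylamino end kept, has no measurable effect here. Nothing in the available data gives a reason for this result. Still open, on these data alone, is how a longer chain, such as 4-(dimethylamino)butyl, would read. So is a chain ending in a carboxylic acid or a morpholine instead of dimethylamino.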